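Cyano in place of hydroxy on the shared core

The compounds below may be only part of what the source reports. "The series", "measured", "known", "first", "only" and "open" are said of these compounds alone.

The series shares the core of compound 1, `Cc1ccc(CNc2ccc(CCC(=O)O)cc2)cc1`, and is tested in a functional assay on CHO cells for agonist activity at Free fatty acid receptor 1 (Homo sapiens), read by reporter gene assay (a higher number here means a larger maximal response, a lower number a smaller maximal response), where compound 1 gives 152%. Compound 2, `CN(C)Cc1ccc(CNc2ccc(CCC(=O)O)cc2)cc1`, gives 12% in this assay, and compound 3, `O=C(O)CCc1ccc(NCc2ccc(O)cc2)cc1`, gives 37%. On these numbers compound 3 stands second highest of the three: nearest to compound 2, with a number 25 percentage points higher from compound 2 to compound 3 (beyond the scatter), and furthest from compound 1, with a number 115 percentage points lower from compound 1 to compound 3 (beyond the scatter). Compound 4, `N#Cc1ccc(CNc2ccc(CCC(=O)O)cc2)cc1`, has not yet been measured; it differs from compound 3 by cyano in place of hydroxy on an aromatic carbon. Among the compounds with values here, no measured step replaces hydroxy by cyano, so the two steps that leave compound 1, a number 140 percentage points lower from compound 1 to compound 2 (beyond the scatter) and a number 115 percentage points lower from compound 1 to compound 3 (beyond the scatter), bear on it only loosely: both changes at that aromatic carbon cut the response sharply, and the two groups other than methyl sit close together. A step in this assay of a number 13 percentage points higher from compound 3 to compound 4 (beyond the scatter) is therefore expected, modest and uncertain in direction. Compound 4 is estimated at 50%, within 15% to 110%.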

Compound 4, largest response reached (reported as percent of maximum), in percent of the reference or control that the assay uses: 49%
Estimate against measurement, compound 4: 1 percentage points above; the range from low to high includes it.
By their numbers in this assay, from the lowest: compound 2; then compound 3; then compound 4; then compound 1.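

Cyano in place of hydroxy at this aromatic carbon, para to a large group, gives a number 12 percentage points higher from compound 3 to compound 4 (beyond the scatter) in this assay, so a group with no hydrogen-bond donor does modestly better here than one that carries a donor. Cyano also gives a number 37 percentage points higher from compound 2 to compound 4 (beyond the scatter) against the (dimethylamino)methyl group, but it recovers little of the response seen with methyl, with a number 103 percentage points lower from compound 1 to compound 4 (beyond the scatter) for this change. Across these four compounds, methyl gives the highest response at this position, and the hydroxy, cyano and (dimethylamino)methyl groups of compound 3, compound 4 and compound 2 all fall well short of it.

Nothing given here accounts for this order. From the compounds shown here alone, it remains open whether ethyl, chlorine or methoxy at the same aromatic carbon would stay close to compound 1 or drop to the level of compound 4.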